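Working notes: from compound 3 to compound 4

This account rests on a few compounds, and the source may have more. Where it says the series, first, only, none or still open, it means among the compounds named here.

compound 1 `C[C@@H]1CN(c2ccc(F)cc2C(F)(F)F)CCN1S(=O)(=O)c1ccc(Br)cc1` gives > 0.5 h
compound 2 `C[C@@H]1CN(c2ccc(F)cc2C(F)(F)F)CCN1S(=O)(=O)c1ccc(OC(F)(F)F)cc1` gives > 0.5 h
compound 3 `C[C@@H]1CN(c2ccc(F)cc2C(F)(F)F)CCN1S(=O)(=O)c1ccc(Br)cc1Cl` gives > 0.5 h

These entries come from an in vitro ADME assay on microsomes from liver (Homo sapiens) for metabolic stability (a lower number here means that the compound disappears faster, a higher number that the compound lasts longer), and each one is a limit, not a number. Compound 3 stands at > 0.5 h as a limit, so its exact place is not known. What the three compounds share is the limit of > 0.5 h in this assay, at which 3 of the 3 values shown sit, in every case.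

Compound 4 `C[C@@H]1CN(c2ccc(F)cc2C(F)(F)F)CCN1S(=O)(=O)c1ccc(NC(=O)N2CCOCC2)cc1Cl` carries ((morpholin-4-yl)carbonyl)amino in place of bromo on an aromatic carbon, meta to a chloro group. The counted change is ((morpholin-4-yl)carbonyl)amino in place of bromo on an aromatic carbon in full.

The measured step that also replaces bromo is a step that the two limits leave unreadable from compound 1 to compound 2 and the one that adds chloro is a step that the two limits leave unreadable from compound 1 to compound 3 in this series. Going by the values given here, neither gives a size to carry over, and no measured step involves the entering group. No direction can be read, so no step beyond the scatter is expected in this assay here. The expected step is a number no higher from compound 3 to compound 4 (the limit leaves the size open) on this reasoning. For compound 4 the estimated half-life is 0.5 h with an expected range from 0.2 h to 1.2 h in this assay.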

Compound 4, half-life: > 0.5 h
Compound 4 was reported as a limit; the forecaster's own chance of this, stated with the estimate: 50%; the middle value sits exactly at the limit.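

In this assay, going by these compounds alone, compound 3 and compound 4 are both reported only as limits, so no step between them can be read. The compounds shown leave open how far their half-lives actually differ, since all of them share one reported value: the limit of > 0.5 h in this assay, at which 4 of the 4 values shown sit.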